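The source may hold more compounds than are shown below. What is called first, only, known or untested is meant among the compounds shown, and "the series" means these compounds.

In a functional assay on MCF7 cells (Homo sapiens) for cytotoxicity, read by MTT assay, with a stated time of 48 h (a lower number here means a stronger inhibitor, a higher number a weaker inhibitor), compound 1 `COc1cc(C(=O)C2Sc3nnc(-c4cc(OC)c(OC)c(OC)c4)n3NC2c2ccco2)cc(OC)c1OC` gives > 100000 nM, which is a limit of the assay. Compound 2 `COc1cc(-c2nnc3n2NC(c2ccco2)C(C(=O)c2cccc4ccccc24)S3)cc(OC)c1OC` gives > 100000 nM in this assay, also a limit. The step that the two limits leave unreadable from compound 1 to compound 2 is therefore unreadable in size and direction. All that the two measured values show is the limit of > 100000 nM in this assay, at which 2 of the 2 values shown sit.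

Compound 3 `COc1cc(-c2nnc3n2NC(c2ccco2)C(C(=O)c2cccc(Br)c2)S3)cc(OC)c1OC` differs from compound 2 in one place: 3-bromophenyl in place of naphthalen-1-yl on a carbonyl carbon. Going by the values given here, no measured step bears directly on this change; the only step on record concerns a different exchange at the same carbonyl carbon and runs between two limits, so no size or direction can be drawn from it. With compound 2 at the limit, compound 3 is expected to remain at or near that limit, with no readable step beyond the scatter. The expected step is a number no higher from compound 2 to compound 3 (the limit leaves the size open). The estimate for compound 3 is 100000 nM, with a range from 30000 nM to 300000 nM.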

Compound 3, half-maximal inhibitory concentration: 91800 nM
The estimate for compound 3 lay 1.1-fold (0.04 log units) above the measured number, within the range that was stated.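

Going by these compounds alone, with 3-bromophenyl on the carbonyl carbon, this assay gives a number rather than a limit for the first time, so a step at this position can at last be given a floor. The data give an at least 1.0-fold lower number from compound 2 to compound 3 (0.03 log units; that floor lies within the scatter) and an at least 1.0-fold lower number from compound 1 to compound 3 (0.03 log units; that floor lies within the scatter) as the readable steps at this position, and neither floor shows a real change. The number for compound 3 therefore stays close to the limit that holds the other compounds: the limit of > 100000 nM in this assay, at which 2 of the 3 values shown sit.

As far as these compounds go, it remains open whether any group on this carbonyl carbon can bring the number far below that limit. A phenyl ring carrying an amine or a carboxylic acid in place of the bromine would be one test, and the compounds shown do not speak to it.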